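The compounds below may be only part of what the source reports. "The series", "measured", "known", "first", "only" and "open" are said of these compounds alone.

Measured compounds:
compound 1, `C=CCOC(=O)C1=C(C)NC(C)=C(C(=O)OC)C1c1cccc([N+](=O)[O-])c1`, 15 nM
compound 2, `C#CCCOC(=O)C1=C(C)NC(C)=C(C(=O)OC)C1c1cccc([N+](=O)[O-])c1`, 31 nM
compound 3, `COC(=O)C1=C(C)NC(C)=C(C(=O)OCC(C)[N+](=O)[O-])C1c1cccc([N+](=O)[O-])c1`, 108 nM

In a functional assay on HEK293 cells for antagonist activity at Voltage-dependent L-type calcium channel subunit alpha-1C (Oryctolagus cuniculus), read by FLIPR (on this read-out lower numbers stand for stronger inhibition and higher numbers for weaker inhibition), compound 3 gives the highest number of the three. Its nearest neighbour is compound 2, seen in the step of a 3.5-fold higher number from compound 2 to compound 3 (0.54 log units; beyond the scatter), and compound 1 lies further off, as the step of a 7.2-fold higher number from compound 1 to compound 3 (0.86 log units; beyond the scatter) shows. Both steps are beyond the scatter, so within this small set the ester carrying the nitro group stands apart from the two esters built from an unsaturated hydrocarbon chain.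

Compound 4, `COC(=O)C1=C(C)NC(C)=C(C(=O)OC2C=CCCC2)C1c1cccc([N+](=O)[O-])c1`, takes the next step from compound 3: cyclohex-2-en-1-yl in place of 2-nitropropyl on an oxygen next to a carbonyl group. The new group, like the groups of compound 1 and compound 2, is a hydrocarbon with one double bond outside aromatic rings and no hydrogen-bond acceptors, whereas the group that leaves carried two acceptors. Within the data shown here, the steps that bear on the change are those from compound 1 and compound 2 to compound 3, both of which ran upward by a modest amount. Reversing that kind of change is expected to move the number in this assay downward again, though the ring in the entering group has no direct counterpart among the measured compounds, so the size is uncertain. Compound 4 is therefore estimated at 30 nM, within 8 nM to 120 nM, a step of a 3.6-fold lower number from compound 3 to compound 4 (0.56 log units; beyond the scatter).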

Compound 4, half-maximal inhibitory concentration: 10 nM
Beside the measured number, compound 4's estimate is 3.0-fold (0.48 log units) above it; the measured number falls inside the stated range.
By their numbers in this assay, from the lowest: compounds 4 and 1 (each within the scatter of the next); then compound 2; then compound 3.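

In this assay, cyclohex-2-en-1-yl in place of 2-nitropropyl on an oxygen next to a carbonyl group gives the largest step in the set (an 11-fold lower number from compound 3 to compound 4 (1.03 log units; beyond the scatter)), and it shows that this position tolerates a six-membered ring of carbon only, which the open-chain esters could not show. The ring ester also separates from the but-3-yn-1-yl ester (a 3.1-fold lower number from compound 2 to compound 4 (0.49 log units; beyond the scatter)), but it cannot be told apart from the allyl ester (a 1.5-fold lower number from compound 1 to compound 4 (0.18 log units; within the scatter)), so a hydrocarbon ring and a short allyl chain serve equally well here in this read-out. Nothing available accounts for any of these steps.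

The compounds shown leave open whether the double bond of the ring matters, which the plain cyclohexyl ester would test, and whether a cycloheptyl or phenyl group would hold the number at this level. They also leave open whether the higher number of compound 3 goes with the nitro group itself or with its branched chain, a question that an isopropyl or n-propyl ester would help to settle.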